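Replacing nitro with propanoylamino in the chloropropoxy series

The source may report more compounds than this note shows. Statements on the series, on what has been measured and on what is new or still open speak of the compounds shown alone.

- compound 1 `COc1ccc(NC(=O)c2ccc(OCCCN(C)C)c([N+](=O)[O-])c2)cc1`: 127000 nM
- compound 2 `COc1ccc(NC(=O)c2ccc(OCCCCl)c([N+](=O)[O-])c2)cc1`: 39700 nM

In a toxicity assay on Huh-7.5 cells (Homo sapiens) for inhibition, read by MTT assay, with a stated time of 96 h (on this read-out lower numbers stand for higher toxicity in this test and higher numbers for lower toxicity in this test), compound 2 has the lower of the two numbers, at 39700 nM. Compound 3 `CCC(=O)Nc1cc(C(=O)Nc2ccc(OC)cc2)ccc1OCCCCl` carries propanoylamino in place of nitro on an aromatic carbon, ortho to a 3-chloropropoxy group (propanoylamino in place of nitro on an aromatic carbon). Among the measured compounds shown here, no measured step touches this place. For the measured compounds named here, the only guide to size is a 3.2-fold lower number from compound 1 to compound 2 (0.51 log units; beyond the scatter), a modest step on a saturated chain carbon. No step beyond the scatter is therefore expected, and the data give no direction. The expected step is a 1.1-fold higher number from compound 2 to compound 3 (0.05 log units; within the scatter). Compound 3 is estimated at 45000 nM, with an expected range of 15000 nM to 110000 nM.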

Compound 3, half-maximal cytotoxic concentration: 158000 nM
Estimate against measurement, compound 3: 3.5-fold (0.55 log units) below, and the stated range ends below it.
By their numbers in this assay, from the lowest: compound 2; then compounds 1 and 3 (each within the scatter of the next).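

In this assay, the aromatic carbon ortho to a 3-chloropropoxy group proves sensitive to substitution: propanoylamino in place of nitro gives a 4.0-fold higher number from compound 2 to compound 3 (0.60 log units; beyond the scatter). Among the compounds shown here, this is the first step at this position, and it runs towards lower toxicity in this test, whereas the earlier step on the saturated chain ran towards higher toxicity. Nothing available explains the shift. Still open, from the compounds shown here alone, is whether the step carries over to the dimethylamino chain of compound 1, and how a free amine or an acetylamino group at this carbon would read.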